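The compounds below may be only part of what the source reports. "The series", "measured", "known", "first", "only" and "open" are said of these compounds alone.

Measured compounds:
- compound 1 `COc1cc(-c2cc(/C=C/C(=O)c3ccc(Cl)c(Cl)c3)[nH]n2)cc(OC)c1OC`: 7660 nM in a functional assay on HOP-62 cells (Homo sapiens) for inhibition, read by sulforhodamine B assay, with a stated time of 48 h; a higher number here means a weaker inhibitor of growth, a lower number a stronger inhibitor of growth
- compound 2 `COc1ccc(C(=O)/C=C/c2cc(-c3cc(OC)c(OC)c(OC)c3)n[nH]2)cc1OC`: 2770 nM in this assay

Compound 2 stands at the lowest of the two numbers; the only other, compound 1, sits above it by a 2.8-fold lower number from compound 1 to compound 2 (0.44 log units; beyond the scatter). Compound 3 `COc1cc(-c2cc(/C=C/C(=O)c3ccc(F)c(F)c3)[nH]n2)cc(OC)c1OC` differs from compound 2 by 3,4-difluorophenyl in place of 3,4-dimethoxyphenyl on a carbonyl carbon. Going by the values given here, one measured step bears on this: a 2.8-fold lower number from compound 1 to compound 2 (0.44 log units; beyond the scatter), where a dichlorophenyl was exchanged for a dimethoxyphenyl on the same carbonyl carbon. Compound 3 moves back toward a twice-halogenated ring, so a modestly higher number is expected, roughly a 2.0-fold higher number from compound 2 to compound 3 (0.30 log units; within the scatter). Compound 3 is therefore estimated at 5500 nM, within 2000 nM to 15000 nM.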

Compound 3, concentration for total growth inhibition: > 100000 nM
Compound 3 was reported as a limit; the forecaster's own chance of this, stated with the estimate: 5%; at least 18-fold (1.25 log units) between middle value and limit.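

For compound 3 the reading in this assay is a limit, not a number: the limit of > 100000 nM in this assay, at which 1 of the 3 values shown sits.

Even so, the ring on the carbonyl carbon matters far more than the first pair suggested, with 3,4-difluorophenyl giving an at least 36-fold higher number from compound 2 to compound 3 (1.55 log units; beyond the scatter) and an at least 13-fold higher number from compound 1 to compound 3 (1.11 log units; beyond the scatter). Two rings that each carry two halogens therefore do not read alike at this place, so the presence of halogens alone does not set the number.

Why 3,4-difluorophenyl departs so far from 3,4-dichlorophenyl stays open. So does how a ring bearing an amine or a carboxylic acid at this place would read.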